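This account rests on a few compounds, and the source may have more. Where it says the series, first, only, none or still open, it means among the compounds named here.

Compound 1, `N#C/C(=C\c1c(-c2ccccc2)[nH]c2ccccc12)C(=O)c1ccccc1`, was tested in a functional assay on MDA-MB-468 cells (Homo sapiens) for inhibition, read by sulforhodamine B assay, with a stated time of 48 h (on this read-out lower numbers stand for stronger inhibition of growth and higher numbers for weaker inhibition of growth), where it gives 5600 nM. Among the measured compounds shown here, that number is the higher of the two so far gathered in this assay: compound 2, `COc1ccc(-c2[nH]c3ccc(OC)cc3c2C=C(C#N)C#N)cc1`, gives 503 nM, and the two structures differ in more than one place, so their values can only be set side by side. Compound 1 thus stands at the weaker end of what has been measured.

Compound 3, `N#C/C(=C\c1c(-c2ccccc2)[nH]c2ccccc12)S(=O)(=O)c1ccccc1`, has not yet been measured in this assay. It differs from compound 1 in one respect: phenylsulfonyl in place of benzoyl on a double-bonded chain carbon bound to a double-bonded chain carbon and a triple-bonded carbon. For the measured compounds named here, no measured pair in this set shows what such an exchange does in this assay, so the expectation for compound 3 rests on compound 1 alone. The step of a 1.2-fold lower number from compound 1 to compound 3 (0.09 log units; within the scatter) is expected to be small and could fall in either direction, with no confident change beyond the usual scatter. Compound 3 is therefore estimated at 4500 nM in this assay, with a range from 1200 nM to 18000 nM to allow for the absence of any directly comparable measurement.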

Compound 3, concentration for 50% growth inhibition: 1900 nM
The estimate for compound 3 lay 2.4-fold (0.37 log units) above the measured number, and the stated range covers the measured number.
By their numbers in this assay, from the lowest: compound 2; then compound 3; then compound 1.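

In this assay, phenylsulfonyl in place of benzoyl on a double-bonded chain carbon bound to a double-bonded chain carbon and a triple-bonded carbon gives a 2.9-fold lower number from compound 1 to compound 3 (0.47 log units; beyond the scatter), a modest step but one beyond the usual scatter. Among the compounds shown here, this is the first comparison in the set that changes a single place, and it shows that growth inhibition at this position responds to what is attached there, even with the rest of the structure held fixed. Both groups carry one six-membered aromatic ring of carbon only, so the step goes with the exchange of the link to that ring rather than with the presence of the ring itself, but nothing at hand explains why the number moves.

The compounds shown leave open whether the same exchange would give a similar step on another core, since this single pair is the only reading of it. They also leave open how a methylsulfonyl group, a carboxylic ester or an amide, none of which carries that aromatic ring in the same way, would fare on this carbon.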